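Bromo for Methoxy on the Thiazole Aryl Group

The compounds below may be only part of what the source reports. "The series", "measured", "known", "first", "only" and "open" are said of these compounds alone.

Measured compounds:
compound 1, `COc1ccc(C2=NN(c3nc(-c4ccc(Br)cc4)cs3)C(c3ccc4c(c3)OCCO4)C2)cc1`: 2540 nM
compound 2, `COc1ccc(-c2csc(N3N=C(c4ccc(Br)cc4)CC3c3ccc4c(c3)OCCO4)n2)cc1`: 870 nM

In a functional assay on MCF7 cells (Homo sapiens) for antiproliferative activity, read by MTT assay, with a stated time of 48 h (on this read-out lower numbers stand for stronger inhibition and higher numbers for weaker inhibition), compound 1 gives 2540 nM. In the same assay compound 2 gives 870 nM. Compound 2 thus stands at the lowest of the two numbers, and its nearest neighbour, compound 1, sits above it by a gap beyond the usual scatter. For the measured compounds named here, the two measured compounds do not differ in a single place, so no step of that kind is available to lean on.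

Compound 3 `Brc1ccc(C2=NN(c3nc(-c4ccc(Br)cc4)cs3)C(c3ccc4c(c3)OCCO4)C2)cc1` follows from compound 2 through (bromo in place of methoxy on an aromatic carbon). Since nothing measured here shows how this change plays out in this assay, only a modest step in either direction is expected, and the estimated step reads a 1.4-fold higher number from compound 2 to compound 3 (0.14 log units; within the scatter). Compound 3 is therefore expected to give 1200 nM, with a range from 400 nM to 4000 nM.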

Compound 3, half-maximal inhibitory concentration: 320 nM
Estimate against measurement, compound 3: 3.8-fold (0.57 log units) above; measured number below the stated range.
By their numbers in this assay, from the lowest: compound 3; then compound 2; then compound 1.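

In this assay, the change from 4-methoxyphenyl to 4-bromophenyl on the thiazole aryl group now has a measured direction, with a 2.7-fold lower number from compound 2 to compound 3 (0.43 log units; beyond the scatter) as bromo replaces methoxy. The same change on the other aryl group of the core gives a 7.9-fold lower number from compound 1 to compound 3 (0.90 log units; beyond the scatter) and so points the same way, which means that among these three compounds bromo goes with the lower number at both places, each resting on a single pair. Nothing available here accounts for either step.

On these data alone, whether a chloro, a hydroxy or an amine in the same place would carry on this trend or break it remains open. It is also unknown whether either step would hold if the shared core carried a longer chain in place of these groups.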